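Swapping the pyrazole for tert-butyl on compound 3

The compounds below may be only part of what the source reports. "The series", "measured", "known", "first", "only" and "open" are said of these compounds alone.

Measured in a functional assay on MCF7 cells (Homo sapiens) for inhibition, read by CCK-8 assay, with a stated time of 48 h; a lower number here means a stronger inhibitor, a higher number a weaker inhibitor:
- Compound 1 `COc1cc(-c2ccnc3cc(-c4cccc(C)c4)nn23)cc(OC)c1OC`: 1080 nM
- Compound 2 `CCOC(=O)c1ccc(-c2cc3nccc(-c4cc(OC)c(OC)c(OC)c4)n3n2)cc1`: > 10000 nM (a limit of the assay)
- Compound 3 `COc1cc(-c2ccnc3cc(-c4ccc(-c5cnn(C)c5)cc4)nn23)cc(OC)c1OC`: 274 nM

Compound 3 gives 274 nM, the lowest number of the three, and its gap to compound 1 at 1080 nM lies beyond the scatter. Compound 2 gives > 10000 nM, which is a limit and not a number.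

The next compound, compound 4 `COc1cc(-c2ccnc3cc(-c4ccc(C(C)(C)C)cc4)nn23)cc(OC)c1OC`, keeps the shared core of compound 3 but carries tert-butyl in place of 1-methyl-1H-pyrazol-4-yl on an aromatic carbon. Going by the values given here, only one measured step changes a group at this place: an at least 36-fold lower number from compound 2 to compound 3 (1.56 log units; beyond the scatter). That large step shows that a change here can move the number strongly in this assay, and 1-methyl-1H-pyrazol-4-yl was the group entering in it. Neither of the other two compounds carries that group, and both sit higher, with none going against this among the three. Still, tert-butyl itself has never been measured here, so the size stays uncertain.

A rise beyond the scatter is therefore expected, estimated as a 5.5-fold higher number from compound 3 to compound 4 (0.74 log units; beyond the scatter). For compound 4 the expected value is 1500 nM, with an estimated range of 400 nM to 7000 nM.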

Compound 4, half-maximal inhibitory concentration: > 10000 nM
Compound 4: only a limit was reported; the forecaster's own chance of this, stated with the estimate: 10%; middle value at least 6.6-fold (0.82 log units) from the limit.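

In this assay compound 4 gives > 10000 nM, which is a limit of the assay, so the low number of compound 3 does not hold for every group at this place on the six-membered aromatic ring. Exchanging 1-methyl-1H-pyrazol-4-yl for tert-butyl on the shared core gives an at least 36-fold higher number from compound 3 to compound 4 (1.56 log units; beyond the scatter), which shows that the earlier gain depends on the group that enters as well as on the loss of ethoxycarbonyl, while the comparison of 4-(tert-butyl)phenyl with 3-methylphenyl gives an at least 9.2-fold higher number from compound 1 to compound 4 (0.96 log units; beyond the scatter). The step between compound 2 and compound 4 cannot be read, as both stop at the same limit: the limit of > 10000 nM in this assay, at which 2 of the 4 values shown sit.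

The change from 1-methyl-1H-pyrazol-4-yl to tert-butyl alters several things at once, including the ring, the nitrogen atoms and the hydrogen-bond acceptors, so the compounds shown cannot say which of these matters. A plain phenyl ring would keep a ring without nitrogen and a dimethylamino group would keep nitrogen without a ring, so either group at this place would help to separate these features.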